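This account rests on a few compounds, and the source may have more. Where it says the series, first, only, none or still open, it means among the compounds named here.

The measured compounds in a functional assay on LoVo cells (Homo sapiens) for inhibition, read by MTT assay, with a stated time of 48 h; a lower number here means a stronger inhibitor, a higher number a weaker inhibitor:

compound 2, `COc1ccc(N(C)c2nc(C)nc3ccccc23)cc1`: 8 nM
compound 1, `COc1ccc(N(C)c2nc(C)nc3ccccc23)cc1C(=O)OCCC[Se]C#N`: 854 nM
compound 3, `COc1ccc(N(C)c2nc(C)nc3ccccc23)cc1OCCCCCC[Se]C#N`: 8580 nM

Compound 3 stands highest of the three numbers. Its nearest neighbour is compound 1, the gap being a 10-fold higher number from compound 1 to compound 3 (1.00 log units; beyond the scatter); the furthest is compound 2, the gap being a 1100-fold higher number from compound 2 to compound 3 (3.03 log units; beyond the scatter).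

Compound 4, `COc1ccc(N(C)c2nc(C)nc3ccccc23)cc1C[Se]C#N`, differs from compound 3 in one place: a group of 4 heavy atoms (2 carbon, 1 nitrogen, 1 selenium; no ring) in place of a group of 10 heavy atoms (7 carbon, 1 nitrogen, 1 oxygen, 1 selenium; no ring), on an aromatic carbon.

Within the data shown here, two measured steps bear directly on this change. The step of a 1100-fold higher number from compound 2 to compound 3 (3.03 log units; beyond the scatter) shows that placing the larger group on this aromatic carbon of compound 2 raised the number strongly, and the step of a 110-fold lower number from compound 1 to compound 2 (2.03 log units; beyond the scatter) shows the same for the other large group. The step of a 10-fold higher number from compound 1 to compound 3 (1.00 log units; beyond the scatter) indicates that, of the two large groups, the larger one gave the higher number. Compound 4 carries a group of only 4 heavy atoms at this position, so the expectation is a large step downward from compound 3, though not all the way back to the value of compound 2, since the carbon is no longer unsubstituted. For compound 4 the expected step is a 43-fold lower number from compound 3 to compound 4 (1.63 log units; beyond the scatter). Compound 4 is therefore estimated at 200 nM, with a range from 30 nM to 1500 nM.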

Compound 4, half-maximal inhibitory concentration: 277 nM
For compound 4 the middle estimate is 1.4-fold (0.14 log units) below the measured one; measured number inside the range.
By their numbers in this assay, from the lowest: compound 2; then compound 4; then compound 1; then compound 3.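

In this assay, replacing the group of 10 heavy atoms with the group of 4 heavy atoms on this aromatic carbon, ortho to a methoxy group, recovers much of the lost ground, with a 31-fold lower number from compound 3 to compound 4 (1.49 log units; beyond the scatter). Even this small group is not equivalent to hydrogen, however, as a 35-fold higher number from compound 2 to compound 4 (1.54 log units; beyond the scatter) shows, and the step of a 3.1-fold lower number from compound 1 to compound 4 (0.49 log units; beyond the scatter) also places it below the group of 9 heavy atoms, so that across these four compounds the number rises with the heavy-atom count at this carbon and none goes against that order. Nothing measured here accounts for this trend.

These compounds do not separate the size of the group from its make-up, as the group of 4 heavy atoms also has no oxygen, whereas both larger groups carry it, and the selenium and nitrile are present in all three substituted compounds. A methyl group or an amine at this carbon would show whether the order depends on heavy-atom count alone or on the selenium and nitrile as well.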